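Benzyl Ether Addition to a Sugar Core: Expected Potency

The source may report more compounds than this note shows. Statements on the series, on what has been measured and on what is new or still open speak of the compounds shown alone.

This account follows compound 2, whose structure is `O[C@@H]1[C@@H](O)[C@H](Cc2ccccc2)O[C@H](COCc2ccccc2)[C@H]1O`, toward compound 4, whose structure is `O[C@@H]1[C@@H](O)[C@H](Cc2ccccc2)O[C@H](COCc2ccccc2)[C@H]1OCc1ccccc1`. In a functional assay on HL-60 cells (Homo sapiens) for antiproliferative activity, read by MTT assay (on this read-out lower numbers stand for stronger inhibition and higher numbers for weaker inhibition), compound 2 is reported as "not active" (no number reported), so no single number places it on the scale. The other measured compounds give numbers: compound 1, with structure `CC1(C)OC[C@@H]2O[C@H](COCc3ccccc3)[C@@H](OCc3ccccc3)[C@H](OCc3ccccc3)[C@H]2O1`, gives 12500 nM in this assay, and compound 3, with structure `O[C@@H]1[C@@H](OCc2ccccc2)[C@H](O)[C@@H](COCc2ccccc2)O[C@H]1Cc1ccccc1`, gives 35300 nM. The change from compound 2 to compound 4 is benzyl in place of hydrogen on an oxygen on a saturated carbon, read one bond further out as hydroxy to benzyloxy. Because compound 3 gives 35300 nM, compound 4, which likewise carries two benzyl ethers, is expected to reach a measurable number rather than none, with weak inhibition. Compound 4 is estimated at 35000 nM, within 12000 nM to 100000 nM.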

Compound 4, half-maximal inhibitory concentration: 26600 nM
Compound 4: the middle estimate sits 1.3-fold (0.12 log units) above what was measured; the measured number falls inside the stated range.
By their numbers in this assay, from the lowest: compound 1; then compounds 4 and 3 (each within the scatter of the next).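

Compound 2 is reported as not active without a number, so its change to compound 4 cannot be read as a step. The compounds shown leave open what size the hydroxy to benzyloxy change has, and no evidence here accounts for the result.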